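Swapping the sulfonamide cap on a chlorinated coumarin imine

The source may report more compounds than this note shows. Statements on the series, on what has been measured and on what is new or still open speak of the compounds shown alone.

Three compounds share a core in which a chlorinated coumarin is linked through an imine to a benzenesulfonamide. In a functional assay on MCF7 cells (Homo sapiens) for cytotoxicity, read by CCK-8 assay, with a stated time of 48 h (on this read-out higher numbers stand for weaker inhibition and lower numbers for stronger inhibition), compound 1 `Cc1cc(NS(=O)(=O)c2ccc(/N=C/c3c(Cl)c4ccccc4oc3=O)cc2)no1` gives 12 nM. Compound 2 `Cc1ccc2oc(=O)c(/C=N/c3ccc(S(N)(=O)=O)cc3)c(Cl)c2c1` gives 270 nM, and compound 3 `Cc1ccc2oc(=O)c(/C=N/c3ccc(S(=O)(=O)NC(=N)N)cc3)c(Cl)c2c1` gives 67 nM, placing compound 3 second highest of the three. Among the measured compounds shown here, the one step measured on this sulfonamide nitrogen, a 4.0-fold lower number from compound 2 to compound 3 (0.61 log units; beyond the scatter), shows that the cap there moves the number. Compound 4 `Cc1ccc2oc(=O)c(/C=N/c3ccc(S(=O)(=O)Nc4cc(C)on4)cc3)c(Cl)c2c1` carries the change (a group of 6 heavy atoms (4 carbon, 1 nitrogen, 1 oxygen; one five-membered aromatic ring with 2 hetero atoms) in place of a group of 3 heavy atoms (1 carbon, 2 nitrogen; no ring), on a sulfonamide nitrogen). For the measured compounds named here, compound 1, which bears the same oxazolyl cap on a core lacking the methyl group, sits well below compound 3, though no single-change step joins them. Compound 4 is therefore expected to fall by a 3.4-fold lower number from compound 3 to compound 4 (0.53 log units; beyond the scatter), giving an estimated 20 nM with a range from 6 nM to 70 nM.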

Compound 4, half-maximal inhibitory concentration: 16 nM
Compound 4: middle estimate off by 1.3-fold (0.10 log units), on the high side; low and high end bracket the measured number.
By their numbers in this assay, from the lowest: compounds 1 and 4 (each within the scatter of the next); then compound 3; then compound 2.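

In this assay, the 5-methyl-1,2-oxazol-3-yl cap on the sulfonamide nitrogen gives a 4.2-fold lower number from compound 3 to compound 4 (0.62 log units; beyond the scatter), and set against a bare hydrogen there it gives a 17-fold lower number from compound 2 to compound 4 (1.23 log units; beyond the scatter), so this position carries a large step on the shared core. Methyl in place of hydrogen on an aromatic carbon, by contrast, gives only a 1.3-fold higher number from compound 1 to compound 4 (0.12 log units; within the scatter). Nothing measured here explains why the cap moves the number. Going by these compounds, whether a different ring on that nitrogen, such as phenyl or pyridine, would match this cap remains open. So does the effect of a simple acetyl group there.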